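The source may hold more compounds than are shown below. What is called first, only, known or untested is meant among the compounds shown, and "the series" means these compounds.

Of the compounds shown here, two have been measured in a functional assay on MDA-MB-231 cells (Homo sapiens) for cytotoxicity, read by MTT assay, with a stated time of 72 h; a lower number here means a stronger inhibitor, a higher number a weaker inhibitor. Compound 1, with the structure `COc1cc2c(Oc3ccc(NC(=O)c4nn(-c5ccccc5F)c(=O)c5ccccc45)cc3F)ccnc2cc1OCCCN1CCN(C)CC1`, gives 1050 nM. Compound 2, with the structure `COc1cc2c(Oc3ccc(NC(=O)c4nn(-c5ccccc5)c(=O)c5ccccc45)cc3F)ccnc2cc1OCCCN1CCC(C)CC1`, gives 1480 nM. Compound 2 thus has the higher of the two numbers, but its nearest neighbour is compound 1, whose number is lower by an amount that falls within the usual scatter of repeated measurements, so the two results cannot be told apart.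

The next step leads from compound 2 to compound 3, whose structure is `COc1cc2c(Oc3ccc(NC(=O)c4nn(-c5ccccc5F)c(=O)c5ccccc45)cc3F)ccnc2cc1OCCCN1CCC(C)CC1`. The change is fluoro in place of hydrogen on an aromatic carbon, on a six-membered aromatic ring of carbon only, ortho to a large group, which reads as phenyl to 2-fluorophenyl. Within the data shown here, compound 1 already carries this 2-fluorophenyl and gives 1050 nM, a number indistinguishable from that of compound 2, although compound 1 and compound 3 also differ elsewhere, so no measured pair isolates this change.

For this assay, a step from compound 2 to compound 3 of no size beyond the scatter is expected, in either direction, and compound 3 is expected to give about 1300 nM, within the range 600 nM to 2800 nM, an expected step of a 1.1-fold lower number from compound 2 to compound 3 (0.06 log units; within the scatter).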

Compound 3, half-maximal inhibitory concentration: 670 nM
For compound 3 the middle estimate is 1.9-fold (0.29 log units) above the measured one; measured number inside the range.
By their numbers in this assay, from the lowest: compounds 3, 1 and 2 (each within the scatter of the next, the first and the last beyond it).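

In this assay, among these compounds, the change from phenyl to 2-fluorophenyl gives a 2.2-fold lower number from compound 2 to compound 3 (0.34 log units; beyond the scatter) with the 4-methylpiperidin-1-yl group held the same, so this is the first pair to isolate fluoro in place of hydrogen on this aromatic carbon, and the step is modest but beyond the scatter. With 2-fluorophenyl present in both compounds, the change of 4-methylpiperazin-1-yl to 4-methylpiperidin-1-yl gives a 1.6-fold lower number from compound 1 to compound 3 (0.20 log units; within the scatter) and stays within the scatter, so these results do not separate those two groups at the end of the chain. No measurement offered here accounts for the gain from the fluoro group.

The fluoro step is known only with 4-methylpiperidin-1-yl on the chain, so the compounds shown do not tell whether it would be of similar size with 4-methylpiperazin-1-yl there. They also leave open whether chloro or methoxy on the same aromatic carbon, or morpholin-4-yl at the end of the chain, would give a number that differs beyond the scatter.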